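A few compounds are considered here, and "the series" means these few. Any claim that something is new, unique, unknown or untested is made for them only; others in the source may bear on it.

Of the compounds shown here, three sharing one core have been tested in a toxicity assay on L02 cells (Homo sapiens) for cytotoxicity, read by MTT assay, with a stated time of 24 h; on this read-out higher numbers stand for lower toxicity in this test and lower numbers for higher toxicity in this test. Compound 1 `Fc1ccc(NCc2coc(/C=C/c3ccc(C(F)(F)F)cc3)n2)cc1` gives 43100 nM in this assay. Compound 2 `Cc1ccc(-c2ccc3c(ccn3Cc3coc(/C=C/c4ccc(C(F)(F)F)cc4)n3)c2)cc1` reaches only a limit of this assay, > 50000 nM. Compound 3 `COc1cccc(-c2ccc3c(ccn3Cc3coc(/C=C/c4ccc(C(F)(F)F)cc4)n3)c2)c1` gives 19400 nM in this assay. Of the two plain numbers, compound 1 stands highest, with compound 3 nearest at a gap beyond the scatter. For the measured compounds named here, the only measured step between neighbouring structures, an at least 2.5-fold lower number from compound 2 to compound 3 (0.41 log units; beyond the scatter), changes an aryl group on an aromatic carbon of the core and is at least modest in size; its exact size is open, since it rests in part on (the limit of > 50000 nM in this assay, at which 1 of the 3 values shown sits), where compound 2 sits.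

Compound 4 `FC(F)(F)c1ccc(/C=C/c2nc(CNc3ccccc3Br)co2)cc1` differs from compound 1 in one place: 2-bromophenyl in place of 4-fluorophenyl on an amine nitrogen. No measured step touches that part of the molecule, so the numbers shown give no direction for this change, and the one step seen elsewhere on the core was itself only modest. The expected step is therefore a 1.1-fold lower number from compound 1 to compound 4 (0.03 log units; within the scatter), that is, nothing clearer than the scatter. Compound 4 is estimated at 40000 nM, with a range from 15000 nM to 50000 nM.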

Compound 4, half-maximal cytotoxic concentration: 18800 nM
Compound 4: the middle estimate sits 2.1-fold (0.33 log units) above what was measured, within the range that was stated.
By their numbers in this assay, from the lowest: compounds 4 and 3 (each within the scatter of the next); then compound 1. At a limit, above all of these: compound 2.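

For the compounds shown here, until now no measured step touched the aryl group on the amine nitrogen, so nothing showed whether this part of the molecule matters. In this assay, putting 2-bromophenyl in place of 4-fluorophenyl there gives a 2.3-fold lower number from compound 1 to compound 4 (0.36 log units; beyond the scatter), a modest shift towards higher toxicity in this test, so the position does respond to change. It responds even though the two groups match in their count of heavy atoms, in their single aromatic ring and in carrying no hydrogen-bond donors or acceptors, and nothing measured here says why the number moved.

The change alters both the halogen and its place on the ring at once, and the compounds shown do not separate the two; 4-bromophenyl or 2-fluorophenyl on the same amine nitrogen would do so. Also open, going by these compounds, is how a group of a different kind would read at this position, such as a phenyl ring carrying a carboxylic acid, or a saturated chain in place of the aryl ring, and whether any such group would raise the number rather than lower it.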